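The compounds below may be only part of what the source reports. "The series", "measured", "known", "first", "only" and "open" are said of these compounds alone.

Compound 1 `O=C(O)[C@@H]1NC[C@@H](O)[C@@H](O)[C@H]1O` gives 8.2%; compound 2 `O=C(O)[C@H]1NCC=C[C@@H]1O` gives 25%; compound 3 `O=C(O)[C@H]1NCC=C[C@H]1O` gives 0.2%.

In an assay for inhibition of alpha-N-acetylgalactosaminidase (Gallus gallus), tested at 1000 uM (a higher number here means more inhibition at the concentration tested (going by the name of the read-out), a lower number less inhibition), compound 1 stands second highest of the three numbers: its gap to compound 3 lies within the scatter, while compound 2 sits beyond the scatter above it. Compound 4 `O=C(O)[C@@H]1NC[C@@H](O)[C@H](O)[C@@H]1O` has not yet been measured. It differs from compound 1 in that (the two compounds have the same atoms and bonds and differ only in configuration as drawn: 2 of 4 stereo elements differ; a stereocentre at a saturated ring carbon is drawn R in compound 1 and S in compound 4; a stereocentre at a saturated ring carbon is drawn S in compound 1 and R in compound 4). Within the data shown here, the one measured step that bears on this is a number 24.8 percentage points lower from compound 2 to compound 3 (beyond the scatter), which rests on the fact that compounds 2 and 3 differ only in the configuration as drawn: a single inverted centre shifts the read-out by a modest amount. Here two centres are inverted, so a step of similar size in this assay is expected, in either direction, though compound 1 leaves little room downward. Compound 4 is therefore expected to give 15% (range 0% to 45%), an estimated step of a number 6.8 percentage points higher from compound 1 to compound 4 (within the scatter).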

Compound 4, a percentage reported as inhibition, at one concentration (the size of the read-out at that concentration, not a potency): 10%
The estimate for compound 4 lay 5 percentage points above the measured number; low and high end bracket the measured number.
By their numbers in this assay, from the lowest: compounds 3, 1 and 4 (each within the scatter of the next); then compound 2.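

With two centres at saturated ring carbons inverted, this assay shows a number 1.8 percentage points higher from compound 1 to compound 4 (within the scatter), so this pair is not separated, although the only thing that sets it apart is: the fact that compounds 1 and 4 differ only in the configuration as drawn. Among these compounds, the single inversion gave a number 24.8 percentage points lower from compound 2 to compound 3 (beyond the scatter), so a change of configuration does not always move this read-out beyond the scatter; it depends on the compounds concerned.

As far as these compounds go, whether either inversion alone would shift the number remains open, since both occur together here. Also open, from the compounds shown here alone, is how an amide in place of the carboxylic acid would read in this assay.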